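A few compounds are considered here, and "the series" means these few. Any claim that something is new, unique, unknown or untested is made for them only; others in the source may bear on it.

Four compounds share one core and differ at two places. Compound 1 `CN1CCN(c2ccc(Nc3ncc(/N=C/c4ccccc4)c(NC4CCCC4)n3)cc2)CC1` carries phenyl and cyclopentyl; compound 2 `CN1CCN(c2ccc(Nc3ncc(/N=C/c4cccs4)c(NC4CCCC4)n3)cc2)CC1` is the thiophen-2-yl partner of compound 1; compound 3 `CC(C)Nc1nc(Nc2ccc(N3CCN(C)CC3)cc2)ncc1/N=C/c1ccccc1` carries isopropyl with phenyl; compound 4 `CC(C)Nc1nc(Nc2ccc(N3CCN(C)CC3)cc2)ncc1/N=C/c1cccs1` joins the isopropyl of compound 3 with the thiophen-2-yl of compound 2.

In a functional assay on HCT-116 cells (Homo sapiens) for antiproliferative activity, read by MTT assay (a lower number here means a stronger inhibitor, a higher number a weaker inhibitor), compound 1 gives 35200 nM. In this assay compound 2 gives 18900 nM. The difference between them, (thiophen-2-yl in place of phenyl on a carbon with a double bond to nitrogen), made a 1.9-fold lower number from compound 1 to compound 2 (0.27 log units; within the scatter). For compound 3 this assay reports only a limit, > 100000 nM. That limit is the limit of > 100000 nM in this assay, at which 1 of the 3 values shown sits. The cores of compound 1 and compound 3 differ by isopropyl in place of cyclopentyl on a nitrogen on an aromatic ring, and this made an at least 2.8-fold higher number from compound 1 to compound 3 (0.45 log units; beyond the scatter).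

The change from compound 3 to compound 4 is thiophen-2-yl in place of phenyl on a carbon with a double bond to nitrogen, the same change as that from compound 1 to compound 2, at a place described in the same words. Because that change made a 1.9-fold lower number from compound 1 to compound 2 (0.27 log units; within the scatter), a step of the same kind is expected here, a number no higher from compound 3 to compound 4 (the limit leaves the size open). Compound 3 stands at a limit, and the number for compound 4 is expected to lie near that limit, with a real chance that this assay again reports only a limit. Compound 4 is estimated at 100000 nM.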

Compound 4, half-maximal inhibitory concentration: > 100000 nM
Compound 4: no number, only a limit (the forecaster's own chance of this, stated with the estimate: 60%); the middle value lies on the limit itself.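

Isopropyl in place of cyclopentyl on a nitrogen on an aromatic ring made an at least 5.2-fold higher number from compound 2 to compound 4 (0.72 log units; beyond the scatter) in this assay, so the cyclopentyl compound has a measured number and the isopropyl compound stands at a limit of the assay, with thiophen-2-yl as with phenyl. The direction of this change therefore carries from the core of compound 1 to the core of compound 2, but each size is open at its upper end, and nothing shows whether the two sizes match: the same change on two cores in this assay, an at least 2.8-fold higher number (0.45 log units; beyond the scatter) from compound 1 to compound 3 and an at least 5.2-fold higher number (0.72 log units; beyond the scatter) from compound 2 to compound 4; the limit leaves it open whether they differ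

The step from compound 3 to compound 4 cannot be read, as both values are limits, so thiophen-2-yl in place of phenyl has a readable step only on the core of compound 1, where it lies within the scatter, and the isopropyl pair cannot show whether that holds: the limit of > 100000 nM in this assay, at which 2 of the 4 values shown sit.

The compounds shown leave open how the number responds to other groups on that nitrogen, such as cyclohexyl or a longer chain such as n-butyl, and so whether the step tracks anything beyond this single pair of groups. Also open, as far as these compounds go, is whether another ring on the carbon with a double bond to nitrogen, such as furan-2-yl or pyridin-3-yl, would move the number beyond the scatter on the core of compound 1.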